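The source may hold more compounds than are shown below. What is called first, only, known or untested is meant among the compounds shown, and "the series" means these compounds.

Compound 1 `CCn1c(N)c(-c2nc3ccccc3[nH]2)c2nc(C#N)c(C#N)nc21` is the starting point, and in a functional assay on HL60/MX2 cells (Homo sapiens) for antiproliferative activity, read by MTT assay, with a stated time of 48 h (a higher number here means a weaker inhibitor, a lower number a stronger inhibitor), compound 1 gives > 50000 nM, which is a limit of the assay rather than a number. Compound 3 `N#Cc1nc2c(-c3nc4ccccc4[nH]3)c(N)n(CCO)c2nc1C#N` carries hydroxy in place of hydrogen on a saturated chain carbon, two bonds along the chain from an aromatic nitrogen, and in this assay compound 3 gives > 50000 nM, again a limit. Compound 2 `CN1CCN(CCn2c(N)c(-c3nc4ccccc4[nH]3)c3nc(C#N)c(C#N)nc32)CC1` is the only one of the three with a measured number: in this assay compound 2 gives 6490 nM. The step of an at least 7.7-fold lower number from compound 1 to compound 2 (0.88 log units; beyond the scatter) cannot be sized exactly because of the limit of > 50000 nM in this assay, at which 2 of the 3 values shown sit, but it is clearly beyond the scatter, and the step of an at least 7.7-fold higher number from compound 2 to compound 3 (0.88 log units; beyond the scatter) points the same way. The step that the two limits leave unreadable from compound 1 to compound 3 gives no information.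

Compound 4 `CN1CCN(CCCn2c(N)c(-c3nc4ccccc4[nH]3)c3nc(C#N)c(C#N)nc32)CC1` differs from compound 1 by (4-methylpiperazin-1-yl)methyl in place of hydrogen on a saturated chain carbon, two bonds along the chain from an aromatic nitrogen. The same ring enters as in compound 2, only on a chain one carbon longer, so the step from compound 1 to compound 2 is the closest guide. A step of about that size, in the same direction, is expected for compound 4: an at least 7.1-fold lower number from compound 1 to compound 4 (0.85 log units; beyond the scatter). Compound 4 is therefore estimated at 7000 nM, with a likely range from 1500 nM to 50000 nM.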

Compound 4, half-maximal inhibitory concentration: 3320 nM
Estimate against measurement, compound 4: 2.1-fold (0.32 log units) above, within the range that was stated.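

In this assay, the 4-methylpiperazin-1-yl ring now gives a measured value on a second chain length, so activity with this ring at this position no longer rests on compound 2 alone: the data show an at least 15-fold lower number from compound 1 to compound 4 (1.17 log units; beyond the scatter), and also an at least 15-fold lower number from compound 3 to compound 4 (1.17 log units; beyond the scatter). Both steps can be stated only as minimum sizes, because compound 1 and compound 3 each sit at a limit rather than at a number: the limit of > 50000 nM in this assay, at which 2 of the 4 values shown sit. The 2-(4-methylpiperazin-1-yl)ethyl and 3-(4-methylpiperazin-1-yl)propyl chains cannot be told apart, with a 2.0-fold lower number from compound 2 to compound 4 (0.29 log units; within the scatter), so these two chain lengths give no ranking.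

The compounds shown leave open whether the 4-methylpiperazin-1-yl ring itself matters, or whether another amine on the same chain, such as dimethylamino or morpholin-4-yl, would give similar values. They also leave open whether a longer chain, such as a 4-(4-methylpiperazin-1-yl)butyl group, would stay level with compound 2 and compound 4 or move clearly away from them.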